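Swapping the fluoroalkene arm for an aminomethylcyclohexyl ring

The source may report more compounds than this note shows. Statements on the series, on what has been measured and on what is new or still open speak of the compounds shown alone.

Measured compounds:
compound 1 `C/C(CN)=C(/F)CN(C[C@H]1Cc2ccccc2CN1)[C@H]1CCCc2cccnc21` gives 44 nM
compound 2 `N[C@H]1CC[C@H](CN(C[C@H]2Cc3ccccc3CN2)[C@H]2CCCc3cccnc32)CC1` gives 280 nM
compound 3 `C/C(CN)=C(\F)CN(C[C@H]1Cc2ccccc2CN1)[C@H]1CCCc2cccnc21` gives 28 nM

In a functional assay on CCRF-CEM cells for antagonist activity at C-X-C chemokine receptor type 4 (Homo sapiens), read by calcium flux, with stated times of 25 min and 90 s (a lower number here means a stronger inhibitor, a higher number a weaker inhibitor), compound 3 gives the lowest number of the three. Its nearest neighbour is compound 1, and the step of a 1.6-fold lower number from compound 1 to compound 3 (0.20 log units; within the scatter) stays within the scatter, which is unsurprising because of the fact that compounds 1 and 3 differ only in the configuration as drawn. The furthest is compound 2, and the step of a 10-fold lower number from compound 2 to compound 3 (1.00 log units; beyond the scatter) lies beyond the scatter.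

Compound 4 `NC[C@H]1CC[C@H](CN(C[C@H]2Cc3ccccc3CN2)[C@H]2CCCc3cccnc32)CC1` differs from compound 3 by one change: 4-(aminomethyl)cyclohexyl in place of 2-(aminomethyl)-1-fluoroprop-1-en-1-yl on a saturated chain carbon bound to an amine nitrogen. The entering group closely resembles the 4-aminocyclohexyl group of compound 2, differing only by the extra methylene that carries the amine. Among the compounds with values here, two measured steps bear on this. The step of a 10-fold lower number from compound 2 to compound 3 (1.00 log units; beyond the scatter) and the step of a 6.4-fold higher number from compound 1 to compound 2 (0.80 log units; beyond the scatter) both show that replacing the fluoroalkene arm by a cyclohexyl ring carrying an amine moves the number upward by a modest amount, beyond the scatter. The same direction is therefore expected here, in this assay, though the extra methylene leaves the exact size uncertain.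

Compound 4 is expected to give about 200 nM, with a range from 60 nM to 700 nM. The expected step is a 7.1-fold higher number from compound 3 to compound 4 (0.85 log units; beyond the scatter).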

Compound 4, half-maximal inhibitory concentration: 340 nM
Compound 4: the middle estimate sits 1.7-fold (0.23 log units) below what was measured; the range from low to high includes it.
By their numbers in this assay, from the lowest: compounds 3 and 1 (each within the scatter of the next); then compounds 2 and 4 (each within the scatter of the next).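

The replacement of 2-(aminomethyl)-1-fluoroprop-1-en-1-yl by 4-(aminomethyl)cyclohexyl raises the number in this assay from either drawn alkene geometry, with a 12-fold higher number from compound 3 to compound 4 (1.08 log units; beyond the scatter) and a 7.7-fold higher number from compound 1 to compound 4 (0.89 log units; beyond the scatter), and these two steps are close to a single comparison made twice: the fact that compounds 1 and 3 differ only in the configuration as drawn. New here is a test of the reach of the amine on the ring, where aminomethyl in place of amino on a saturated ring carbon gives a 1.2-fold higher number from compound 2 to compound 4 (0.08 log units; within the scatter), so the added methylene does not separate these two compounds. Among the four compounds shown, both cyclohexyl compounds therefore stand apart from both fluoroalkene compounds, whichever of the two amine arrangements the ring carries.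

The compounds shown do not tell whether the step follows from the arrival of the ring or from the departure of the fluoroalkene, a question that an open saturated chain such as 4-aminobutyl or a phenyl ring carrying aminomethyl could help to separate. The part played by the fluorine itself also stays open, as every alkene shown carries it and none has a plain hydrogen in its place.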